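The source may hold more compounds than are shown below. What is called first, only, known or untested is meant among the compounds shown, and "the series" means these compounds.

Measured so far:
Compound 1, `O=S(=O)(Nc1ccccc1)c1cccc(Br)c1`, gives 8.25.
Compound 2, `O=[N+]([O-])c1cccc(S(=O)(=O)Nc2ccccc2)c1`, gives 7.5.
Compound 3, `O=S(=O)(Nc1ccc(Cl)cc1)c1ccc(Br)cc1`, gives 8.24.

All three numbers come from an ADME assay. Compound 1 and compound 2 differ in one place: nitro in place of bromo on an aromatic carbon. That change gave a number 0.75 log units lower from compound 1 to compound 2 (beyond the scatter). Compound 3 sits on a different core; the difference between the core of compound 1 and the core of compound 3 is not broken down here. The value of compound 3 and the value of compound 1 lie within the scatter of each other, so no order between them is claimed.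

Compound 4, `O=[N+]([O-])c1ccc(S(=O)(=O)Nc2ccc(Cl)cc2)cc1`, has not yet been measured. It comes from compound 3 by the same kind of change: nitro in place of bromo on an aromatic carbon. The place differs from the earlier change, which sat meta to a large group, whereas here the nitro sits para to a large group. Because compound 1 to compound 2 showed a number 0.75 log units lower from compound 1 to compound 2 (beyond the scatter), a drop of similar size is expected from compound 3 to compound 4, estimated as a number 0.79 log units lower from compound 3 to compound 4 (beyond the scatter). For compound 4 in this assay the estimate is 7.45, expected to fall between 7.15 and 7.75.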

Compound 4, acid dissociation constant: 6.24
Estimate against measurement, compound 4: 1.21 log units above; the measured number lies below the stated range.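

In this assay, nitro in place of bromo on the second core gave a number 2.00 log units lower from compound 3 to compound 4 (beyond the scatter). The direction matches the earlier step, but the size of the change does not carry over unchanged from one core to the other: the same change on two cores in this assay, a number 0.75 log units lower (beyond the scatter) from compound 1 to compound 2 and a number 2.00 log units lower (beyond the scatter) from compound 3 to compound 4, 1.25 log units apart, beyond the scatter of two such steps. These two pairs differ both in their cores and in where the nitro sits, so they do not show whether the core, the place or both account for the gap, and two pairs alone set no rule for the series.

The compounds shown leave open how a nitrile or an amine in place of bromo would compare on either core. They also leave open what a nitro para to a large group would give on the core of compound 1, a comparison that would separate the effect of the place from that of the rest of the core.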